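The source may report more compounds than this note shows. Statements on the series, on what has been measured and on what is new or still open speak of the compounds shown alone.

Measured in an ADME assay on microsomes from liver for inhibition of cytochrome P450 2B1 (Rattus norvegicus); on this read-out lower numbers stand for stronger inhibition and higher numbers for weaker inhibition:
- compound 1, `Cc1ccc2[nH]c(C)nc2c1`: 479000 nM
- compound 2, `CCc1nc2cc(C)ccc2[nH]1`: 269000 nM
- compound 3, `CCCc1nc2cc(C)c(C)cc2[nH]1`: 110000 nM

Compound 1 and compound 2 share one core and differ by methyl in place of hydrogen on a saturated chain carbon bound to an aromatic carbon. In this assay this gives a 1.8-fold lower number from compound 1 to compound 2 (0.25 log units; within the scatter), so the two cannot be ranked against each other. Compound 3 sits on a different core; how that core differs from the core of compound 1 is not broken down here. Compound 3 gives the lowest of the three numbers, and the gap to compound 2 as well as the gap to compound 1 lies beyond the scatter, so compound 3 is the strongest inhibitor measured so far in this assay.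

Compound 4, `CCCCc1nc2cc(C)c(C)cc2[nH]1`, is not yet measured. It differs from compound 3 by methyl in place of hydrogen on a saturated chain carbon, three bonds along the chain from an aromatic carbon. This is the same kind of change as from compound 1 to compound 2, but not the same: there the methyl enters on a saturated chain carbon bound to an aromatic carbon, here on a saturated chain carbon three bonds along the chain from an aromatic carbon. The step from compound 3 to compound 4 in this assay is expected to be a 1.8-fold lower number from compound 3 to compound 4 (0.26 log units; within the scatter), resting on the earlier step of a 1.8-fold lower number from compound 1 to compound 2 (0.25 log units; within the scatter) and on compound 3, which carries the longest chain, giving the lowest number at 110000 nM. Compound 4 is accordingly estimated at 60000 nM, expected to fall between 25000 nM and 150000 nM.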

Compound 4, half-maximal inhibitory concentration: 55000 nM
Compound 4: middle estimate off by 1.1-fold (0.04 log units), on the high side, within the range that was stated.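

In this assay, methyl in place of hydrogen on a saturated chain carbon, three bonds along the chain from an aromatic carbon, gives a 2.0-fold lower number from compound 3 to compound 4 (0.30 log units; within the scatter). Set beside the earlier methyl step on the other core, the size of the step shows no difference that can be told apart, so within this pair the change carries from one core to the other without a visible shift: the same change on two cores in this assay, a 1.8-fold lower number (0.25 log units; within the scatter) from compound 1 to compound 2 and a 2.0-fold lower number (0.30 log units; within the scatter) from compound 3 to compound 4, 1.1-fold (0.05 log units) apart, within the scatter of two such steps
This does not show that the change itself moves the number, as each step alone lies within the scatter, and two steps with the methyl entering at different places on the chain are too few to support a rule for other cores or other chain positions.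

The compounds shown leave open what a longer chain, such as pentyl or hexyl, would give on either core, and whether any single step of this kind would clear the scatter. They also leave open how a branched chain, or a chain ending in an amine or a carboxylic acid, would read in this assay.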